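Chloro to Hydrogen on the Shared Core: One Step Repeated

The compounds below may be only part of what the source reports. "The series", "measured", "known", "first", "only" and "open" are said of these compounds alone.

The measured compounds:
compound 1, `ClCc1ccc(Cn2cnc3nc(Cl)nc(Cl)c32)cc1`, gives 7410 nM in a functional assay on 786-0 cells (Homo sapiens) for cytotoxicity, read by sulforhodamine B assay, with a stated time of 48 h; a lower number here means that less compound is tolerated, a higher number that more compound is tolerated;
compound 2, `ClCc1ccccc1Cn1cnc2ncnc(Cl)c21`, gives 47900 nM;
compound 3, `ClCc1ccccc1Cn1cnc2nc(Cl)nc(Cl)c21`, gives 30900 nM.

Compound 3 and compound 2 differ by hydrogen in place of chloro on an aromatic carbon. The step of a 1.6-fold higher number from compound 3 to compound 2 (0.19 log units; within the scatter) lies within the scatter. Compound 1 and compound 3 are built from the same atoms joined differently; the difference between the two cores is not broken down here. Compound 1 gives the lowest number of the three, beyond the scatter from both others.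

Compound 4, `ClCc1ccc(Cn2cnc3ncnc(Cl)c32)cc1`, is not yet measured. It differs from compound 1 by hydrogen in place of chloro on an aromatic carbon, the same change as from compound 3 to compound 2. In this assay compound 4 is expected to give 11900 nM, with a range from 5000 nM to 30000 nM. The expected step of a 1.6-fold higher number from compound 1 to compound 4 (0.21 log units; within the scatter) rests on a 1.6-fold higher number from compound 3 to compound 2 (0.19 log units; within the scatter).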

Compound 4, concentration lethal to 50% of the cells: 5490 nM
Beside the measured number, compound 4's estimate is 2.2-fold (0.34 log units) above it; the range from low to high includes it.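

Putting hydrogen in place of chloro on the core of compound 1 gives a 1.3-fold lower number from compound 1 to compound 4 (0.13 log units; within the scatter) in this assay. Set beside the same change on the other core, the two steps do not differ: the same change on two cores in this assay, a 1.6-fold higher number (0.19 log units; within the scatter) from compound 3 to compound 2 and a 1.3-fold lower number (0.13 log units; within the scatter) from compound 1 to compound 4, 2.1-fold (0.32 log units) apart, within the scatter of two such steps. On both cores the change thus stays within the scatter, but this rests on two pairs alone, shows no direction for the change, and says nothing about any core beyond these two.

The compounds shown leave open what another group would do on that aromatic carbon between two ring nitrogen atoms, such as an amine or a methoxy group. They also leave open whether such a group would carry over from one core to the other.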